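Methoxy in Place of Bromo: Expected Cytotoxicity of Compound 4

This account rests on a few compounds, and the source may have more. Where it says the series, first, only, none or still open, it means among the compounds named here.

Compound 1 `Fc1ccc(-c2nn(-c3ccccc3)cc2-c2nc3cc(Br)ccc3[nH]2)cc1` was tested in an ADME assay on HaCaT cells (Homo sapiens) for cytotoxicity, read by MTT assay, with a stated time of 48 h (a lower number here means a stronger inhibitor, a higher number a weaker inhibitor), and compound 1 gave 21800 nM. Compound 2 `COc1ccc2[nH]c(-c3cn(-c4ccccc4)nc3-c3ccc(F)cc3)nc2c1` reached only the limit of this assay, and for compound 2 the result is > 50000 nM. Compound 3 `COc1ccc(-c2nn(-c3ccccc3)cc2-c2nc3cc(Br)ccc3[nH]2)cc1` likewise reached only a limit, and for compound 3 the result is > 50000 nM. The change methoxy in place of bromo on an aromatic carbon brought an at least 2.2-fold higher number from compound 1 to compound 2 (0.36 log units; beyond the scatter). The other change, (methoxy in place of fluoro on an aromatic carbon), which is also how the core of compound 3 differs from that of compound 1, brought an at least 2.2-fold higher number from compound 1 to compound 3 (0.36 log units; beyond the scatter). Both steps can only be given as lower bounds because of the limit of > 50000 nM in this assay, at which 2 of the 3 values shown sit.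

Compound 4 `COc1ccc(-c2nn(-c3ccccc3)cc2-c2nc3cc(OC)ccc3[nH]2)cc1` has not yet been tested in this assay. It differs from compound 3 by methoxy in place of bromo on an aromatic carbon, which is the same change that turned compound 1 into compound 2, with the same place on the same ring. Since compound 3 already stands at the limit, and the earlier step was an at least 2.2-fold higher number from compound 1 to compound 2 (0.36 log units; beyond the scatter), the expected step is a step that the limit leaves unreadable from compound 3 to compound 4, with the reservation that an at-least bound cannot be added to a limit with precision. On that basis compound 4 is expected to give about 80000 nM in this assay, most likely reported again as a limit, somewhere between 30000 nM and 250000 nM.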

Compound 4, half-maximal inhibitory concentration: > 50000 nM
Compound 4 gave a limit, no number; the forecaster's own chance of this, stated with the estimate: 85%; the middle value is on the limit's open side.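

In this assay compound 4 gave > 50000 nM, which is a limit and not a number. For the compounds shown here, no step from compound 2 or compound 3 to compound 4 can be read, because all three compounds stand at the same limit: the limit of > 50000 nM in this assay, at which 3 of the 4 values shown sit. The compounds shown leave open how far compound 2, compound 3 and compound 4 each lie past that limit, and whether they differ from one another at all.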